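Swapping a Ring Methyl for a Tolyl Group

The source may report more compounds than this note shows. Statements on the series, on what has been measured and on what is new or still open speak of the compounds shown alone.

Compound 3 `CC(C(=O)NCc1ccc(C(F)(F)F)nc1N1CCN(C)CC1)c1ccc(NS(C)(=O)=O)c(F)c1` stands at the weaker end of the three measured compounds: in a functional assay on CHO-K1 cells for antagonist activity at transient receptor potential cation channel subfamily V member 1 (Homo sapiens), read by FLIPR (on this read-out lower numbers stand for stronger inhibition and higher numbers for weaker inhibition), compound 3 gives 146 nM. Compound 1 `CC(C(=O)NCc1ccc(C(F)(F)F)nc1N1CCC(=O)CC1)c1ccc(NS(C)(=O)=O)c(F)c1` gives 91 nM in this assay, and the step of a 1.6-fold higher number from compound 1 to compound 3 (0.21 log units; within the scatter) is too small to rank the two. Compound 2 `CC(C)OC1CCN(c2nc(C(F)(F)F)ccc2CNC(=O)C(C)c2ccc(NS(C)(=O)=O)c(F)c2)CC1` gives 3 nM, the lowest number of the set, and the steps of a 49-fold higher number from compound 2 to compound 3 (1.69 log units; beyond the scatter) and a 30-fold lower number from compound 1 to compound 2 (1.48 log units; beyond the scatter) are both large. Compound 4 `Cc1cccc(N2CCN(c3nc(C(F)(F)F)ccc3CNC(=O)C(C)c3ccc(NS(C)(=O)=O)c(F)c3)CC2)c1` differs from compound 3 by 3-methylphenyl in place of methyl on an amine nitrogen in a ring. Among the measured compounds shown here, no measured step changes the group on that ring nitrogen, so the evidence is indirect. The step of a 30-fold lower number from compound 1 to compound 2 (1.48 log units; beyond the scatter) shows that putting a larger group at the far end of the ring on the shared core gave a much lower number, and by that analogy compound 4 is expected to give a lower number than compound 3, a step of a 7.3-fold lower number from compound 3 to compound 4 (0.86 log units; beyond the scatter). The estimate for compound 4 in this assay is 20 nM, with a range from 3 nM to 150 nM.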

Compound 4, inhibition constant: 3.4 nM
Beside the measured number, compound 4's estimate is 5.9-fold (0.77 log units) above it, within the range that was stated.
By their numbers in this assay, from the lowest: compounds 2 and 4 (each within the scatter of the next); then compounds 1 and 3 (each within the scatter of the next).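

In this assay, among the compounds shown here, 3-methylphenyl in place of methyl on the amine nitrogen in the ring gives a 43-fold lower number from compound 3 to compound 4 (1.63 log units; beyond the scatter) and is the first direct test of this position, which clearly tolerates a much larger group carrying a six-membered aromatic ring of carbon only. The earlier large steps replaced the whole group on the aromatic carbon, whereas here the ring stays and only its nitrogen substituent changes, bringing compound 4 at 3.4 nM within the scatter of compound 2 at 3 nM in this read-out. No measurement shown explains the size of this step.

The compounds shown leave open whether the methyl on the aromatic ring matters, a question for plain phenyl on the same nitrogen. They also leave open whether any aromatic ring is needed, a question for cyclohexyl there.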